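Adding one methoxy to the aromatic ring of compound 3

The source may hold more compounds than are shown below. What is called first, only, known or untested is meant among the compounds shown, and "the series" means these compounds.

- compound 1 `COc1cc(/C=C/C(=O)/C=C/c2cccc3ccccc23)ccc1OCc1cn(CCCOc2cc(=O)oc3ccccc23)nn1`: 12700 nM
- compound 2 `COc1cc(/C=C/C(=O)/C=C/c2cccs2)ccc1OCc1cn(CCOc2cc(=O)oc3ccccc23)nn1`: 11400 nM
- compound 3 `COc1ccc(/C=C/C(=O)/C=C/c2ccc(OCc3cn(CCCOc4cc(=O)oc5ccccc45)nn3)c(OC)c2)cc1OC`: 13000 nM

In a functional assay on COLO 205 cells (Homo sapiens) for cytotoxicity, read by sulforhodamine B assay, with a stated time of 48 h (a higher number here means a weaker inhibitor, a lower number a stronger inhibitor), compound 3, at 13000 nM, cannot be told apart from the other two compounds, since all three lie within the scatter of one another. Compound 4 `COc1cc(/C=C/C(=O)/C=C/c2cc(OC)c(OC)c(OC)c2)ccc1OCc1cn(CCCOc2cc(=O)oc3ccccc23)nn1` differs from compound 3 by methoxy in place of hydrogen on an aromatic carbon, which gives 3,4,5-trimethoxyphenyl in place of 3,4-dimethoxyphenyl. Among the compounds with values here, one measured step bears on this group, a 1.0-fold higher number from compound 1 to compound 3 (0.01 log units; within the scatter), and it exchanged the whole aryl group without leaving the scatter. A smaller change is therefore expected to do no more. The estimated step is a 1.2-fold lower number from compound 3 to compound 4 (0.07 log units; within the scatter), which would stay within the scatter. Compound 4 is expected at 11000 nM, with an estimated range of 5000 nM to 22000 nM.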

Compound 4, half-maximal inhibitory concentration: 10600 nM
Compound 4: the middle estimate sits 1.0-fold (0.02 log units) above what was measured; low and high end bracket the measured number.
By their numbers in this assay, from the lowest: compounds 4, 2, 1 and 3 (each within the scatter of the next).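

In this assay, methoxy in place of hydrogen on an aromatic carbon, ortho to a methoxy group, gives a 1.2-fold lower number from compound 3 to compound 4 (0.09 log units; within the scatter). The larger exchange, 3,4,5-trimethoxyphenyl in place of naphthalen-1-yl, gives a 1.2-fold lower number from compound 1 to compound 4 (0.08 log units; within the scatter), so neither the single added methoxy nor the whole aryl exchange leaves the scatter in these compounds. No available evidence accounts for this result. From the compounds shown here alone, what remains open is whether an amine or a carboxylic acid on this aromatic carbon, in place of methoxy, would move the number beyond the scatter.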